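Fluoro in place of hydrogen on compound 1

The compounds below may be only part of what the source reports. "The series", "measured", "known", "first", "only" and "open" are said of these compounds alone.

In an ADME assay on a cell-free system (plasma, Canis lupus familiaris) for protein binding, tested at 1 ug/mL, compound 1 (`COc1cc2nc(N3CCCN(C(=O)N4CCOCC4)CC3)cc(N)c2c(-c2ccccc2)c1OC`) gives 88%. Within the data shown here, the only other measured compound, compound 2 (`COc1cc2c(cc1OC)CN(c1nc(N3CCCN(C(=O)N4CC(O)C(O)C4)CC3)nc3cc(OC)c(OC)cc13)CC2`), gives 90%. These two values lie within the scatter of each other, so neither stands apart. Among the measured compounds shown here, no two measured compounds differ in one place only, so no measured step guides the next change.

Compound 3 (`COc1cc2nc(N3CCCN(C(=O)N4CCOCC4)CC3)cc(N)c2c(-c2ccc(F)cc2)c1OC`) turns the phenyl of compound 1 into 4-fluorophenyl, with fluoro in place of hydrogen on an aromatic carbon, para to a large group: fluoro in place of hydrogen on an aromatic carbon. No shift beyond the scatter is expected in this assay, and any small movement would be expected toward more binding. The estimated step a 1.2-fold lower unbound fraction from compound 1 to compound 3 (0.08 log units; within the scatter) is expected to stay within the scatter. This expectation rests on compound 1 at 88%. For compound 3 the expected value is 90%, with an estimated range of 82% to 95%.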

Compound 3, plasma protein binding: 96%
The estimate for compound 3 lay 2.5-fold (0.40 log units) (unbound fraction) above the measured number; measured number outside the range, above it.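

Fluoro in place of hydrogen on an aromatic carbon, para to a large group, gives a 3.0-fold lower unbound fraction from compound 1 to compound 3 (0.48 log units; beyond the scatter) in this assay. Among these compounds, this is the first single-place step, and the earlier compounds, which differ in more than one place, could not show whether the phenyl of compound 1 matters for this read-out. The step shows that this position does matter, since one added fluorine atom moves the value beyond the scatter, but no measurement here accounts for the shift.

One step cannot show whether the shift is specific to fluoro or would also follow from another group at this position, such as chloro, methyl, an amine or a carboxylic acid. It also leaves open whether fluoro on another aromatic carbon of the phenyl would give a step of similar size.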